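Swapping an alkene for a cyclopropane in a vanillyl amide

The source may hold more compounds than are shown below. What is called first, only, known or untested is meant among the compounds shown, and "the series" means these compounds.

Compound 1 `CCCCCCCC/C=C\CCCCCCCCCCC(=O)NCc1ccc(O)c(OC)c1` is a long-chain amide of a vanillyl group. In a functional assay on HEK293 cells with transient receptor potential cation channel subfamily V member 1 (Homo sapiens) as the target (a higher number here means that more compound is needed for the effect, a lower number that less compound is needed), compound 1 gives 3.16 nM, level with compound 2 `CCCCCC[C@@H](O)C/C=C\CCCCCCCC(=O)NCc1ccc(O)c(OC)c1`, which in this assay gives 3.16 nM; the two lie within the scatter of each other. Compound 3 `CCCCCCCC[C@H]1C[C@H]1CCCCCCCCCCC(=O)NCc1ccc(O)c(OC)c1` carries a (2-octylcyclopropyl in place of dec-1-en-1-yl on a saturated chain carbon, ten or more bonds along the chain from a carbonyl carbon). Because compound 1 gives 3.16 nM and compound 2 gives 3.16 nM despite differing in their chains, this change is expected to shift the activity little, if at all, beyond the scatter, so the step of a 1.6-fold higher number from compound 1 to compound 3 (0.20 log units; within the scatter) is estimated to be small. Compound 3 is expected to give 5 nM, within 1.5 nM to 20 nM.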

Compound 3, half-maximal effective concentration: 79.4 nM
The estimate for compound 3 lay 16-fold (1.20 log units) below the measured number, and the stated range ends below it.
By their numbers in this assay, from the lowest: compounds 1 and 2 (each within the scatter of the next); then compound 3.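

In this assay, putting 2-octylcyclopropyl in place of dec-1-en-1-yl gives a 25-fold higher number from compound 1 to compound 3 (1.40 log units; beyond the scatter). This swap takes out a double bond and brings in a three-membered ring with two defined stereocentres, and the size of the step shows that this part of the chain does not tolerate the change. Nothing measured here explains the rise.

Going by these compounds, it remains open whether the double bond's removal, the ring or the ring's stereochemistry matters most. A plain decyl group in the same place would help separate these.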